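The source may report more compounds than this note shows. Statements on the series, on what has been measured and on what is new or still open speak of the compounds shown alone.

Measured so far in a functional assay on HOS-TE85 cells (Homo sapiens) for inhibition, read by CCK-8 assay, with a stated time of 72 h; a lower number here means a stronger inhibitor, a higher number a weaker inhibitor: compound 1 `O=C(NCCCCc1ccccc1)c1cccc(C2SCC(=O)N2c2ccccn2)c1` gives 19.7 nM. Compound 2 `CCN1C(=O)CSC1c1cccc(C(=O)NCCCCc2ccccc2)c1` gives > 1000 nM, a limit of the assay. Compound 3 `O=C(NCCCCc1ccccc1)c1cccc(C2SCC(=O)N2c2nccs2)c1` gives > 1000 nM, again a limit of the assay.

Compound 3 thus stands at the limit (the limit of > 1000 nM in this assay, at which 2 of the 3 values shown sit), not at a number. Compound 4 `O=C(NCCCCc1ccccc1)c1cccc(C2SCC(=O)N2c2cnccn2)c1` is not yet measured; it differs from compound 3 by pyrazin-2-yl in place of 1,3-thiazol-2-yl on an amide-type nitrogen in a ring. Among the measured compounds shown here, the steps that bear on this are an at least 50-fold higher number from compound 1 to compound 3 (1.70 log units; beyond the scatter) and an at least 50-fold higher number from compound 1 to compound 2 (1.70 log units; beyond the scatter): both leave pyridin-2-yl and both are large. The step that the two limits leave unreadable from compound 2 to compound 3 cannot be read. Pyrazin-2-yl stands nearer to the pyridin-2-yl of compound 1 than does 1,3-thiazol-2-yl, so a fall in the number is expected, an at least 3.3-fold lower number from compound 3 to compound 4 (0.52 log units; beyond the scatter), though only compound 1 supports it. Compound 4 is estimated at 300 nM, from 40 nM to 2000 nM.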

Compound 4, half-maximal inhibitory concentration: > 1000 nM
Compound 4: only a limit was reported; the forecaster's own chance of this, stated with the estimate: 40%; middle value at least 3.3-fold (0.52 log units) from the limit.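

In this assay compound 4 gives only a limit of the assay, and it joins compounds 2 and 3 there: the limit of > 1000 nM in this assay, at which 3 of the 4 values shown sit. A six-membered aromatic ring on the amide-type nitrogen is therefore not enough on its own, with an at least 50-fold higher number from compound 1 to compound 4 (1.70 log units; beyond the scatter), and pyridin-2-yl remains the only group shown at this position with a measured number. The steps among compounds 2, 3 and 4 cannot be read. Still open, from the compounds shown here alone, is whether these three differ at all beyond the limit, and whether phenyl or pyridin-3-yl on that nitrogen would keep a measurable number.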